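The source may report more compounds than this note shows. Statements on the series, on what has been measured and on what is new or still open speak of the compounds shown alone.

Measured so far in a functional assay for inhibition, with Homo sapiens as the target; a higher number here means a weaker inhibitor, a lower number a stronger inhibitor

Compound 1 `O=C(NC[C@H](NS(=O)(=O)c1ccccc1)C(=O)O)c1cc2cc(OCC3CCNCC3)ccc2[nH]1` gives 13 nM
Compound 2 `Cc1ccc(S(=O)(=O)N[C@@H](CNC(=O)c2cc3cc(OCC4CCNCC4)ccc3[nH]2)C(=O)O)cc1` gives 6 nM

Of these two, compound 2 has the lower number in this assay and is therefore the stronger inhibitor. Within the data shown here, the one measured step, methyl in place of hydrogen on an aromatic carbon, is a 2.2-fold lower number from compound 1 to compound 2 (0.34 log units; beyond the scatter) and is modest, though beyond the scatter.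

Compound 3 `O=C(NC[C@H](NS(=O)(=O)c1cccnc1)C(=O)O)c1cc2cc(OCC3CCNCC3)ccc2[nH]1` carries pyridin-3-yl in place of 4-methylphenyl on a sulfonyl sulfur, and pyridin-3-yl in place of 4-methylphenyl on a sulfonyl sulfur gives the counted difference. This change also removes that methyl, so the measured step bears on it in reverse. Compound 1, which lacks the methyl and gives 13 nM, is therefore the closest guide. Among the measured compounds shown here, no measured compound shows what a ring nitrogen does on a sulfonyl sulfur, so the uncertainty is wide. A modest move towards a higher number is expected, and the estimated change is a 3.0-fold higher number from compound 2 to compound 3 (0.48 log units; beyond the scatter). For compound 3 the expected value is 18 nM, with an estimated range from 6 nM to 55 nM.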

Compound 3, half-maximal inhibitory concentration: 12 nM
Beside the measured number, compound 3's estimate is 1.5-fold (0.18 log units) above it; the range from low to high includes it.
By their numbers in this assay, from the lowest: compounds 2, 3 and 1 (each within the scatter of the next, the first and the last beyond it).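

In this assay pyridin-3-yl in place of phenyl on a sulfonyl sulfur gives a 1.1-fold lower number from compound 1 to compound 3 (0.03 log units; within the scatter) and so shows that, of the compounds shown, the one with a ring nitrogen at this place cannot be told apart from its all-carbon phenyl counterpart. Pyridin-3-yl in place of 4-methylphenyl gives a 2.0-fold higher number from compound 2 to compound 3 (0.30 log units; within the scatter) and so also stays inside the scatter, although this change removes the methyl whose addition gave a 2.2-fold lower number from compound 1 to compound 2 (0.34 log units; beyond the scatter) in the earlier step. Compound 3 therefore cannot be ranked against either compound 1 or compound 2, and no supporting evidence accounts for these results.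

The compounds shown leave open whether the place of the ring nitrogen matters, as pyridin-2-yl or pyridin-4-yl on the sulfonyl sulfur would show, and whether a methyl on the pyridin-3-yl ring would give a step like the one seen on phenyl. They also leave open how this place would respond to a ring carrying an amine or a carboxylic acid, or to a longer chain in place of the aromatic ring.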